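Swapping Iodo for Trifluoromethyl at Two Different Aryl Positions

The compounds below may be only part of what the source reports. "The series", "measured", "known", "first", "only" and "open" are said of these compounds alone.

Compound 1 `O=C(Nc1nnc(-c2ccc(Cl)cc2)s1)c1ccccc1I`: in a functional assay on the whole organism (integument) for inhibition, with Chilo suppressalis as the target, read by scintillation counting, with a stated time of 72 h (a lower number here means a stronger inhibitor, a higher number a weaker inhibitor), compound 1 gives > 5010 nM, a limit of the assay.
Compound 2 `O=C(Nc1nnc(-c2ccc(Cl)cc2)s1)c1ccccc1C(F)(F)F`: in this assay compound 2 gives > 16500 nM, also a limit.
Compound 3 `COc1cccc(OC)c1C(=O)Nc1nnc(-c2ccc(I)cc2)s1`: in this assay compound 3 gives 89.1 nM.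

Compound 4 `COc1cccc(OC)c1C(=O)Nc1nnc(-c2ccc(C(F)(F)F)cc2)s1` has not yet been measured. It differs from compound 3 by trifluoromethyl in place of iodo on an aromatic carbon. The same kind of change separates compound 1 from compound 2, where it is trifluoromethyl in place of iodo on an aromatic carbon; the place is not the same, being ortho to a large group there and para to a large group here. The difference between the core of compound 1 and that of compound 3 is not broken down here.

Compound 1 sits at the limit of > 5010 nM in this assay, at which 1 of the 3 values shown sits. Compound 2 sits at the limit of > 16500 nM in this assay, at which 1 of the 3 values shown sits. The earlier step that the two limits leave unreadable from compound 1 to compound 2 therefore offers no size to lean on.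

Without a readable precedent, the expected step from compound 3 to compound 4 is a modest loss, a 2.5-fold higher number from compound 3 to compound 4 (0.39 log units; beyond the scatter), resting on compound 3 giving 89.1 nM and on the group swap described. Compound 4 is estimated at 220 nM, expected between 60 nM and 900 nM.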

Compound 4, half-maximal inhibitory concentration: 49 nM
Compound 4: the middle estimate sits 4.5-fold (0.65 log units) above what was measured, and the stated range ends above it.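

In this assay, trifluoromethyl in place of iodo, para to a large group, gives a 1.8-fold lower number from compound 3 to compound 4 (0.26 log units; within the scatter), so on this core the two groups cannot be told apart. On the core of compound 1 the step for the same swap cannot be read, since compound 1 and compound 2 both stand at limits of the assay, and the swap lies at a different place there, so nothing shown establishes that the result on one core carries over to the other. The limit of compound 2, one end of that unreadable step, is a limit and not a number: the limit of > 16500 nM in this assay, at which 1 of the 4 values shown sits.

Whether a methyl, a methoxy or a nitrile at the same place on the core of compound 3 would read like iodo and trifluoromethyl stays open among the compounds shown. Also open, as far as these compounds go, are what an amine or a carboxylic acid would do there, and how the swap reads on the core of compound 1 with a number at both ends.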